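From a Methyl Ketone to a Phenyl Ketone

The compounds below may be only part of what the source reports. "The series", "measured", "known", "first", "only" and "open" are said of these compounds alone.

Compound 1 `COc1ccc(-c2[nH]c3ccccc3c2/C=C(\C#N)S(=O)(=O)c2ccccc2)cc1` gives 1300 nM in a functional assay on EKVX cells (Homo sapiens) for inhibition, read by sulforhodamine B assay, with a stated time of 48 h; a lower number here means a stronger inhibitor of growth, a higher number a weaker inhibitor of growth.
Compound 2 `CC(=O)/C(=C\c1c(-c2ccccc2)[nH]c2ccccc12)S(=O)(=O)c1ccccc1` gives 3300 nM in this assay.

Of the two numbers, compound 2 holds the higher one; compound 1 sits lower by a gap beyond the usual scatter, so compound 2 is the weaker of the pair. Compound 3 `O=C(/C(=C\c1c(-c2ccccc2)[nH]c2ccccc12)S(=O)(=O)c1ccccc1)c1ccccc1` differs from compound 2 in one place only: phenyl in place of methyl on a carbonyl carbon. Among the compounds with values here, no measured pair shows this change, so the expectation rests on compound 2 alone and is a step of about a 1.3-fold lower number from compound 2 to compound 3 (0.12 log units; within the scatter), most likely nothing beyond the scatter. Compound 3 is therefore expected near 2500 nM, within a range from 800 nM to 8000 nM.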

Compound 3, concentration for 50% growth inhibition: 4600 nM
Compound 3: the middle estimate sits 1.8-fold (0.26 log units) below what was measured; the measured number falls inside the stated range.
By their numbers in this assay, from the lowest: compound 1; then compounds 2 and 3 (each within the scatter of the next).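

Phenyl in place of methyl on a carbonyl carbon gives a 1.4-fold higher number from compound 2 to compound 3 (0.14 log units; within the scatter) in this assay and so no real change in growth inhibition. This carbonyl carbon can therefore carry a six-membered aromatic ring instead of a single carbon without a shift that the assay can resolve. No measurement shown here explains this result. As far as these compounds go, it remains open whether a longer chain such as propyl, or an amine, on the same carbonyl carbon would also leave the number within the scatter, or would move it clearly in either direction.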